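This account rests on a few compounds, and the source may have more. Where it says the series, first, only, none or still open, it means among the compounds named here.

Measured so far:
compound 1, `Clc1ccc(OCC2=NCCO2)cc1`: 10%
compound 2, `Brc1ccccc1OCC1=NCCO1`: 10%
compound 3, `Clc1ccccc1OCC1=NCCO1`: 40%

All three were run in a toxicity assay on the whole organism with Rattus norvegicus as the target, at a dose of 100 mg/kg by the oral route; on this read-out lower numbers stand for a weaker effect and higher numbers for a stronger effect at the one dose given. Compound 3 and compound 1 share the same atoms joined differently; the difference between the two cores is not broken down here. Compound 1 and compound 2 stand level at the digits read.

One structural change has been measured, from compound 3 to compound 2: bromo in place of chloro on an aromatic carbon. Its step in this assay was a number 30 percentage points lower from compound 3 to compound 2 (beyond the scatter).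

Compound 4, `Brc1ccc(OCC2=NCCO2)cc1`, is not yet measured. It arises from compound 1 by the same kind of change, (bromo in place of chloro on an aromatic carbon), but at a place para to a group of 7 heavy atoms rather than ortho to it. Because compound 1 already gives 10%, little room remains for a step as large as the earlier one, so for compound 4 the expected step is no change at the digits printed from compound 1 to compound 4 (within the scatter), and compound 4 is estimated at 10%, expected between 0% and 25%.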

Compound 4, a percentage reported as activity, at one dose (the size of the read-out at that dose, not a potency): 5%
Compound 4: the middle estimate sits 5 percentage points above what was measured; the measured number falls inside the stated range.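

In this assay, bromo in place of chloro on an aromatic carbon gives a number 5 percentage points lower from compound 1 to compound 4 (within the scatter), so on this core the change does not move the read-out beyond the scatter. The size of the step does not carry over from one core to the other: the same change on two cores in this assay, a number 30 percentage points lower (beyond the scatter) from compound 3 to compound 2 and a number 5 percentage points lower (within the scatter) from compound 1 to compound 4, 25 percentage points apart, beyond the scatter of two such steps. Within the data shown here, two pairs show only that the step cannot be assumed to transfer between these cores; they do not show why the steps differ, or what the change would do on any further core.

Only chloro and bromo appear on the aromatic ring here. Open, from the compounds shown here alone, is how this read-out responds to other groups there, such as fluoro, methoxy, an amine or a carboxylic acid.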